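The source may report more compounds than this note shows. Statements on the series, on what has been measured and on what is new or still open speak of the compounds shown alone.

Working notes on the series. All four compounds share one core; compound 1 `Cc1cc(NCc2nccn2C)n2nc(C)c(-c3ccccc3)c2n1` carries a (1-methyl-1H-imidazol-2-yl)methyl group on the amine nitrogen. In an ADME assay on CHO cells (Cricetulus griseus) for cytotoxicity, read by MTT assay (a lower number here means a stronger inhibitor, a higher number a weaker inhibitor), compound 1 gives < 9000 nM, which is a limit of the assay and not a number. Compound 2 `Cc1cc(NCc2ccccn2)n2ncc(-c3cccc(Cl)c3)c2n1` gives 3780 nM in this assay. Compound 3 `Cc1cc(NCc2ccccn2)n2ncc(-c3ccc(F)c(Cl)c3)c2n1` gives 20000 nM in this assay. Going by the values given here, the only measured step in the set is a 5.3-fold higher number from compound 2 to compound 3 (0.72 log units; beyond the scatter); it sits on the phenyl ring, not on the chain carbon considered here. Where compound 1 stands is fixed only by the limit of < 9000 nM in this assay, at which 1 of the 3 values shown sits.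

Compound 4 `Cc1cc(NCc2ccc(F)cn2)n2nc(C)c(-c3ccccc3)c2n1` differs from compound 1 by 5-fluoropyridin-2-yl in place of 1-methyl-1H-imidazol-2-yl on a saturated chain carbon bound to a nitrogen on an aromatic ring. Among the compounds with values here, no measured step changes this group. Compound 2, which carries a plain pyridin-2-ylmethyl group and gives 3780 nM, differs from compound 4 in more than one place, so it serves only as a rough anchor for what a pyridylmethyl amine does in this assay. With compound 1 known only as a limit, the expected step in this assay is taken as a step that the limit leaves unreadable from compound 1 to compound 4, within the scatter or close to it, in no firm direction. Compound 4 is estimated at 6000 nM, with a range of 1500 nM to 25000 nM, in this assay.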

Compound 4, half-maximal inhibitory concentration: 22000 nM
Compound 4: middle estimate off by 3.7-fold (0.56 log units), on the low side, and the stated range covers the measured number.
By their numbers in this assay, from the lowest: compound 2; then compounds 3 and 4 (each within the scatter of the next).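

In this assay, 5-fluoropyridin-2-yl in place of 1-methyl-1H-imidazol-2-yl on a saturated chain carbon bound to a nitrogen on an aromatic ring gives an at least 2.4-fold higher number from compound 1 to compound 4 (0.38 log units; beyond the scatter). Going by these compounds alone, this is the only step read at this position, and it shows that the number responds to a change here as well as to the change on the phenyl ring, which gives a 5.3-fold higher number from compound 2 to compound 3 (0.72 log units; beyond the scatter). The step starts from a limit of the assay for compound 1, so its true size is not fixed and only its lower bound can be read: the limit of < 9000 nM in this assay, at which 1 of the 4 values shown sits.

The step exchanges the ring and brings in the fluoro group together, so the compounds shown do not separate the two, and compound 2, with its plain pyridin-2-ylmethyl group, differs from compound 4 in more than one place. Also open, from the compounds shown here alone, is how this assay would read with a non-aromatic group such as a carboxylic acid or a dimethylamino group on this chain carbon, and whether the step would hold on a core carrying a substituted phenyl ring like that of compound 2.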